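This account rests on a few compounds, and the source may have more. Where it says the series, first, only, none or still open, it means among the compounds named here.

Compound 2 `Nc1scc(CN2CCN(c3ccc(Cl)c(C(F)(F)F)c3)CC2)c1C(=O)c1ccc(Cl)cc1` is considered in an assay on CHO cells for displacement of a labelled ligand from adenosine receptor A3 (Homo sapiens), read by scintillation counting, with a stated time of 120 min, tested at 10 uM (a higher number here means more inhibition at the concentration tested (going by the name of the read-out), a lower number less inhibition), where compound 2 gives 3%. Among the compounds with values here, its only neighbour, compound 1 `Nc1scc(CN2CCN(c3ccc(Cl)cc3F)CC2)c1C(=O)c1ccc(Cl)cc1`, gives 1% in this assay, and the step of a number 2 percentage points higher from compound 1 to compound 2 (within the scatter) is within the scatter, so compound 2 shows the higher of two numbers without a real difference between them. Compound 3 `Nc1scc(CN2CCN(c3ccccc3F)CC2)c1C(=O)c1ccc(Cl)cc1` has not yet been measured. It differs from compound 2 by 2-fluorophenyl in place of 4-chloro-3-(trifluoromethyl)phenyl on an amine nitrogen in a ring. Within the data shown here, the single measured step at this position, from compound 1 to compound 2, exchanged the group on the amine nitrogen in a ring without moving the read-out, so the expected step of a number 1 percentage points lower from compound 2 to compound 3 (within the scatter) is none beyond the scatter. Compound 3 is therefore estimated at 2%, between -6% and 12%.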

Compound 3, a percentage reported as inhibition, at one concentration (the size of the read-out at that concentration, not a potency): 0%
Beside the measured number, compound 3's estimate is 2 percentage points above it; low and high end bracket the measured number.
By their numbers in this assay, from the lowest: compounds 3, 1 and 2 (each within the scatter of the next).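

In this assay, 2-fluorophenyl in place of 4-chloro-3-(trifluoromethyl)phenyl gives a number 3 percentage points lower from compound 2 to compound 3 (within the scatter), and hydrogen in place of chloro on an aromatic carbon gives a number 1 percentage points lower from compound 1 to compound 3 (within the scatter). The read-out at this position thus stays within the scatter with or without the chloro group, which compound 1 and compound 2, both chlorinated, could not show. Nothing available offers an explanation for this.
The compounds shown leave open whether an amine or a carboxylic acid on that phenyl ring, or a longer alkyl chain in its place on the amine nitrogen, would give a read-out beyond the scatter.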